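Swapping a pentyl chain for a fluorophenyl ring

This account rests on a few compounds, and the source may have more. Where it says the series, first, only, none or still open, it means among the compounds named here.

Compound 1 `CCCOc1ccc(C(=O)Nc2cccc(CC)n2)cc1` gives 37600 nM in an in vitro assay on HEK-tsA201 cells for antagonist activity at Neuronal acetylcholine receptor; alpha4/beta2 (Homo sapiens), read by fluorescence and calcium flux; a higher number here means a weaker inhibitor, a lower number a stronger inhibitor. Compound 2 `CCCCCNc1cccc(NC(=O)c2ccc(OCCC)cc2)n1` reaches only a limit of this assay there, > 100000 nM. The step of an at least 2.6-fold higher number from compound 1 to compound 2 (0.42 log units; beyond the scatter) thus points toward weaker inhibition, and the limit of > 100000 nM in this assay, at which 1 of the 2 values shown sits, marks where compound 2 sits. Compound 3 `CCCOc1ccc(C(=O)Nc2cccc(Nc3ccccc3F)n2)cc1` differs from compound 2 by 2-fluorophenyl in place of pentyl on a nitrogen on an aromatic ring. No measured step covers this kind of exchange; the only step shown replaced an ethyl with a pentylamino group. Compound 3 is expected to remain a weak inhibitor, with a step of an at least 1.2-fold lower number from compound 2 to compound 3 (0.09 log units; that floor lies within the scatter) that stays within the scatter. Compound 3 is estimated at 80000 nM, in a range from 25000 nM to 250000 nM.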

Compound 3, half-maximal inhibitory concentration: > 100000 nM
Compound 3: no number, only a limit; the forecaster's own chance of this, stated with the estimate: 55%; middle value at least 1.2-fold (0.09 log units) from the limit.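

Compound 3 gives only a limit, as compound 2 does, so the step between them cannot be read. Putting (2-fluorophenyl)amino in place of ethyl on this aromatic carbon gives an at least 2.6-fold higher number from compound 1 to compound 3 (0.42 log units; beyond the scatter), so a ring on the nitrogen, like the pentyl chain, stays on the weak side. Compound 2 and compound 3 share one limit: the limit of > 100000 nM in this assay, at which 2 of the 3 values shown sit.

From the compounds shown here alone, how far either compound lies past that limit stays unknown, so chain and ring cannot be ranked. Going by these compounds, whether a plain amine or a methylamino group at this place would restore inhibition also remains open.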